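Three measured amides and an expected fourth

This account rests on a few compounds, and the source may have more. Where it says the series, first, only, none or still open, it means among the compounds named here.

Compound 1 `O=C(/C=C/c1cccc(NC(=O)c2ccccc2Cl)c1)c1nc2ccccc2[nH]1`: 1280 nM in a functional assay on HCT-116 cells (Homo sapiens) for antiproliferative activity, read by MTT assay, with a stated time of 48 h; on this read-out lower numbers stand for stronger inhibition and higher numbers for weaker inhibition
Compound 2 `O=C(Nc1cccc(/C=C/C(=O)c2nc3ccccc3[nH]2)c1)c1cccc(Cl)c1`: 1120 nM in this assay
Compound 3 `O=C(Nc1cccc(/C=C/C(=O)c2nc3ccccc3[nH]2)c1)c1cccc(Br)c1`: 1560 nM in this assay

Compound 3 has the highest of the three numbers, but its steps to the others, a 1.2-fold higher number from compound 1 to compound 3 (0.09 log units; within the scatter) and a 1.4-fold higher number from compound 2 to compound 3 (0.14 log units; within the scatter), both lie within the scatter, so no ordering among the three is claimed. Compound 4 `Cc1ccc(C(=O)Nc2cccc(/C=C/C(=O)c3nc4ccccc4[nH]3)c2)cc1` differs from compound 3 by 4-methylphenyl in place of 3-bromophenyl on a carbonyl carbon. Going by the values given here, no measured step exchanges a halogen for a methyl; what bears on it is that every change made so far on the same ring, a 1.1-fold lower number from compound 1 to compound 2 (0.06 log units; within the scatter), a 1.2-fold higher number from compound 1 to compound 3 (0.09 log units; within the scatter) and a 1.4-fold higher number from compound 2 to compound 3 (0.14 log units; within the scatter), stayed within the scatter. The step expected in this assay is accordingly none beyond the scatter, a 1.1-fold lower number from compound 3 to compound 4 (0.05 log units; within the scatter). Compound 4 is estimated at 1400 nM, with a range from 600 nM to 3500 nM.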

Compound 4, half-maximal inhibitory concentration: 1660 nM
Estimate against measurement, compound 4: 1.2-fold (0.07 log units) below; the range from low to high includes it.
By their numbers in this assay, from the lowest: compounds 2, 1, 3 and 4 (each within the scatter of the next).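

In this assay, a methyl-bearing ring on the carbonyl carbon gives no separation from any of the halogen-bearing rings (a 1.1-fold higher number from compound 3 to compound 4 (0.03 log units; within the scatter); a 1.5-fold higher number from compound 2 to compound 4 (0.17 log units; within the scatter); a 1.3-fold higher number from compound 1 to compound 4 (0.11 log units; within the scatter)). The set of groups at this position that stay within the scatter of one another thus now extends to 4-methylphenyl, a group with no halogen. Nothing shown offers a reason for this sameness.

The compounds shown leave open whether any group at this position would separate from these four. On these data alone, an amine or a carboxylic acid on the ring, or a longer chain in place of the ring, remains untested here.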